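Trimming the Acid Chain: From Compound 2 to Compound 4

A few compounds are considered here, and "the series" means these few. Any claim that something is new, unique, unknown or untested is made for them only; others in the source may bear on it.

Compounds 1, 2 and 3 share a common core and each carries an amide. Compound 1 has the structure `Cn1c(-c2ccc(NC(=O)CN3CCCC3)cc2)nc2cc(C(F)(F)F)ccc21`. Compound 2 has the structure `O=C(O)CCC(=O)Nc1ccc(-c2nc3cc(C(F)(F)F)ccc3[nH]2)cc1`. Compound 3 has the structure `O=C(CN1CCCC1)Nc1ccc(-c2nc3ccccc3[nH]2)cc1`. All three were tested in an ADME assay on BHK cells (Mesocricetus auratus) for cytotoxicity, read by MTT assay, with a stated time of 96 h; a lower number here means that less compound is tolerated, a higher number that more compound is tolerated. Compound 1 gives 27000 nM in this assay. Compound 3 gives 55000 nM. For compound 2 the result is not a number but a limit of the assay, recorded as > 100000 nM. Compound 2 therefore sits at the limit of > 100000 nM in this assay, at which 1 of the 3 values shown sits, so its true value is known only to lie beyond the measured range, whereas compounds 1 and 3 returned numbers within it.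

Compound 4, with the structure `CC(=O)Nc1ccc(-c2nc3cc(C(F)(F)F)ccc3[nH]2)cc1`, has not yet been measured. It differs from compound 2 in one place: hydrogen in place of carboxymethyl on a saturated chain carbon bound to a carbonyl carbon. Within the data shown here, since compound 2 is known only as a limit, no measured step sets a scale for this change; what is known is that the two compounds with a different amide substituent, compounds 1 and 3, returned numbers rather than limits. A modest move toward lower tolerance, or none beyond the scatter, is expected. The step is estimated as an at least 1.4-fold lower number from compound 2 to compound 4 (0.15 log units; that floor lies within the scatter). Compound 4 is expected to give about 70000 nM in this assay, within a range from 30000 nM to 150000 nM, with a fair chance that only a limit is reported.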

Compound 4, half-maximal cytotoxic concentration: 53000 nM
The estimate for compound 4 lay 1.3-fold (0.12 log units) above the measured number, and the stated range covers the measured number.
By their numbers in this assay, from the lowest: compounds 1, 4 and 3 (each within the scatter of the next, the first and the last beyond it). At a limit, above all of these: compound 2.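

Shortening the 2-carboxyethyl to methyl gives this position its first real number: in this assay compound 4 gives 53000 nM, a value inside the measured range. The change can therefore be written as a step with a floor, an at least 1.8-fold lower number from compound 2 to compound 4 (0.27 log units; that floor lies within the scatter), and this floor alone cannot be told apart from the ordinary variation between repeated measurements, though the true step may be larger. The size of the step stays unknown, and its only upper reference is a limit of the assay rather than a number, recorded for compound 2: the limit of > 100000 nM in this assay, at which 1 of the 4 values shown sits.

The compounds shown leave open how large the step really is, and whether it depends on the carboxylic acid itself or on the length of the chain that carries it. A plain propyl chain in place of the 2-carboxyethyl, or a methyl ester in place of the carboxylic acid, would pull these two apart, but this single pair cannot say how either would behave in cells.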